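This account rests on a few compounds, and the source may have more. Where it says the series, first, only, none or still open, it means among the compounds named here.

Two urea compounds sharing one core have been tested in a functional assay on A549 cells (Homo sapiens) for inhibition, read by MTT assay and WST assay, with a stated time of 72 h, tested at 10 uM; on this read-out lower numbers stand for less inhibition of growth and higher numbers for more inhibition of growth at the one concentration tested. Compound 1 `O=C(Nc1ccc(Oc2ccc(-c3ncc[nH]3)cc2)cc1)Nc1ccc(F)c(C(F)(F)F)c1` gives 63.3%. Compound 2 `O=C(Nc1ccc(Oc2ccc(-c3ncc[nH]3)cc2)cc1)Nc1cc(C(F)(F)F)ccc1Cl` gives 22.3%, the lowest of the two numbers shown; the only other compound, compound 1, stands higher, and the step of a number 41 percentage points lower from compound 1 to compound 2 (beyond the scatter) is large and beyond the scatter. Compound 3 `CC(=O)Oc1sccc1NC(=O)Nc1ccc(Oc2ccc(-c3ncc[nH]3)cc2)cc1` is not yet measured. It differs from compound 2 at the very place that the measured step touched: 2-acetoxythiophen-3-yl in place of 2-chloro-5-(trifluoromethyl)phenyl on an amide-type nitrogen. That single step shows that exchanging the ring on this amide-type nitrogen has moved the read-out a long way, but with one step alone there is nothing to tell the direction for a five-membered ring bearing an acetoxy group. The estimate for compound 3 in this assay is therefore 40%, expected to lie between 10% and 75%. This corresponds to an expected step of a number 17.7 percentage points higher from compound 2 to compound 3 (beyond the scatter), with room for either direction.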

Compound 3, percent growth inhibition at one concentration: 2.34%
For compound 3 the middle estimate is 37.7 percentage points above the measured one; measured number outside the range, below it.
By their numbers in this assay, from the lowest: compound 3; then compound 2; then compound 1.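

In this assay, the new group on the amide-type nitrogen brings a number 20 percentage points lower from compound 2 to compound 3 (beyond the scatter), and measured against the other phenyl group it brings a number 61 percentage points lower from compound 1 to compound 3 (beyond the scatter). For the compounds shown here, the earlier pair showed only that two phenyl groups carrying trifluoromethyl can differ widely; this result adds that a five-membered aromatic ring bearing an acetoxy group, 2-acetoxythiophen-3-yl, falls below both of them, leaving compound 3 the lowest of the three. No independent measurement is available to explain this drop.

Compound 3 brings in the thiophene ring and the acetoxy group together, so these compounds cannot show which of the two goes with the lower number. A thiophen-3-yl group without the acetoxy group, or with an amine in its place, would help to separate the two.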